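The source may hold more compounds than are shown below. What is called first, only, known or untested is meant among the compounds shown, and "the series" means these compounds.

Compound 1 `Clc1ccc(OCc2nc3c(OCCC4CCNCC4)cccc3n2CCCC2CCCNC2)cc1` gives the lowest number of the two compounds that return a number in an assay on isolated protein for binding affinity to Neuropeptide Y receptor type 1 (Homo sapiens); a higher number here means a weaker inhibitor, a lower number a stronger inhibitor: compound 1 gives 7 nM. Its nearest neighbour, compound 2 `Clc1ccc(OCc2nc3ccccc3n2CCC2CCCCN2)cc1`, gives 7860 nM. Compound 3 `Clc1ccc(OCc2nc3ccccc3n2CCN2CCCCC2)cc1` returns no number; for compound 3 the assay reports only a limit, > 100000 nM. Among the measured compounds shown here, the one step measured between two compounds that differ in a single place runs from compound 2 to compound 3: an at least 12-fold higher number from compound 2 to compound 3 (1.10 log units; beyond the scatter). That step, read against (the limit of > 100000 nM in this assay, at which 1 of the 3 values shown sits), concerns the chain on the aromatic nitrogen and not the oxygen on the aromatic ring.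

Compound 4 `Oc1cccc2c1nc(COc1ccc(Cl)cc1)n2CCCC1CCCNC1` has not yet been measured in this assay. It differs from compound 1 by hydrogen in place of 2-(piperidin-4-yl)ethyl on an oxygen on an aromatic ring. For the measured compounds named here, no measured step touches this oxygen, so the expectation rests on the values alone. Compound 2, which also carries hydrogen at that oxygen but a different chain on the aromatic nitrogen, sits far from compound 1; that gap mixes two changes and is only a rough guide. Compound 4 is therefore expected to lose much of the affinity of compound 1, with an estimated step of a 71-fold higher number from compound 1 to compound 4 (1.85 log units; beyond the scatter). The estimate for compound 4 in this assay is 500 nM, between 50 nM and 5000 nM.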

Compound 4, inhibition constant: 5300 nM
Beside the measured number, compound 4's estimate is 11-fold (1.03 log units) below it; measured number above the stated range.
By their numbers in this assay, from the lowest: compound 1; then compounds 4 and 2 (each within the scatter of the next). At a limit, above all of these: compound 3.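

Among the compounds shown here, the step of a 760-fold higher number from compound 1 to compound 4 (2.88 log units; beyond the scatter) in this assay is the only measured change at this oxygen on an aromatic ring, and it shows that the low number of compound 1 depends heavily on the 2-(piperidin-4-yl)ethyl group: with a bare hydroxy in its place, most of the affinity is gone. For the compounds shown here, until now, the only single change on record concerned the chain on the aromatic nitrogen, so this is a second place in the molecule where one change produces a large step. Compound 4 still returns a real number, so this step is read from two numbers, and compound 3 alone stands at a limit: the limit of > 100000 nM in this assay, at which 1 of the 4 values shown sits.

The compounds shown treat the 2-(piperidin-4-yl)ethyl group as a whole, so they leave open whether its ring nitrogen, its ring or its chain carries the effect; a 2-cyclohexylethyl, a 2-aminoethyl or a simple methyl on the same oxygen would begin to separate these parts. On these data alone, it also stays open whether the 2-(piperidin-4-yl)ethyl group would bring a similar step on a core with a different chain on the aromatic nitrogen.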